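Acid dissociation notes on the carbamate ester series

This account rests on a few compounds, and the source may have more. Where it says the series, first, only, none or still open, it means among the compounds named here.

Measured so far in a physicochemical assay for acid dissociation:
compound 1, `COC(=O)N(C)COC(=O)Cc1c(C)n(C(=O)c2ccc(Cl)cc2)c2ccc(OC)cc12`: 4.5
compound 2, `COC(=O)N(COC(=O)[C@@H](C)c1ccc2cc(OC)ccc2c1)c1ccccc1`: 4.2
compound 3, `COC(=O)N(COC(=O)[C@@H](C)c1ccc2cc(OC)ccc2c1)c1ccc(OC)cc1`: 4.2

For the measured compounds named here, compound 3 sits level with compound 2; the only single-point step measured, no change at the digits printed from compound 2 to compound 3 (within the scatter), shows that the methoxy on the aromatic carbon left the value unchanged within the scatter. Compound 1, built on a different core, gives a value that is also within the scatter of compound 3, so the three measured numbers do not separate in this assay.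

Compound 4, `CCOC(=O)c1ccc(N(COC(=O)[C@@H](C)c2ccc3cc(OC)ccc3c2)C(=O)OC)cc1`, is reached from compound 3 by ethoxycarbonyl in place of methoxy on an aromatic carbon. Going by the values given here, no measured step tests this substituent; the one step available, no change at the digits printed from compound 2 to compound 3 (within the scatter), concerns a methoxy at the same place and was flat. Nothing measured here points to a shift beyond the scatter for compound 4, but the change is larger than the one measured, so the range is kept wide. The step from compound 3 to compound 4 is expected to be no change at the digits printed from compound 3 to compound 4 (within the scatter). Compound 4 is therefore estimated at 4.2, with a range from 3.8 to 4.6.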

Compound 4, acid dissociation constant: 4.2
For compound 4 middle estimate and measured number coincide at the digits printed, within the range that was stated.
By their numbers in this assay, from the lowest: compounds 2, 3, 4 and 1 (each within the scatter of the next).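

In this assay, ethoxycarbonyl in place of methoxy on the aromatic carbon para to a large group gives no change at the digits printed from compound 3 to compound 4 (within the scatter) even though the entering group has 5 heavy atoms and the leaving group 2, so the flat reading at this position is no longer confined to methoxy. Set against hydrogen at the same place, ethoxycarbonyl gives no change at the digits printed from compound 2 to compound 4 (within the scatter) and thus adds a second substituent that does not separate from the unsubstituted ring, leaving hydrogen, methoxy and ethoxycarbonyl indistinguishable here in this read-out. Nothing on hand offers an independent measurement that would account for this flat outcome.

From the compounds shown here alone, whether the position stays equally flat with an amine, a carboxylic acid or a longer ester chain in the same place remains open, since the three groups compared here span only a narrow set of substituents. For the compounds shown here, it is also open whether a substituent on the core of compound 1 would behave in the same way, as no single-place step connects that compound to the other three.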